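Nitro on the anilino ring: compound 4 from compound 3

The source may hold more compounds than are shown below. What is called first, only, known or untested is meant among the compounds shown, and "the series" means these compounds.

Compound 1, `CCOC(=O)C1=C(Nc2ccccc2)S/C(=C\c2ccc(O)c(O)c2)C1=O`, gives 38.1% in a functional assay on MCF7 cells (Homo sapiens) for inhibition, read by MTT assay, with a stated time of 72 h, tested at 10 uM; on this read-out lower numbers stand for less inhibition and higher numbers for more inhibition at the one concentration tested (going by the name of the read-out).
Compound 2, `CCOC(=O)C1=C(Nc2ccccc2)S/C(=C\c2ccc(C(=O)O)cc2)C1=O`, reaches only a limit of the assay, < 10%.
Compound 3, `CCOC(=O)C1=C(Nc2ccccc2)S/C(=C\c2ccc[nH]2)C1=O`, gives 18.3%.

Among the numbers shown, compound 3 stands lowest of the two; the step of a number 19.8 percentage points lower from compound 1 to compound 3 (beyond the scatter) lies beyond the scatter. The limit of compound 2 is one of the values, as the limit of < 10% in this assay, at which 1 of the 3 values shown sits, notes. The step of a number at least 28.1 percentage points lower from compound 1 to compound 2 (beyond the scatter) and the step of a number at least 8.3 percentage points higher from compound 2 to compound 3 (that floor lies within the scatter) complete the measured comparisons. Every one of these steps exchanges the group on the double-bonded chain carbon; none touches the ring on the other side of the shared core.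

Compound 4, `CCOC(=O)C1=C(Nc2cccc([N+](=O)[O-])c2)S/C(=C\c2ccc[nH]2)C1=O`, differs from compound 3 there: nitro in place of hydrogen on an aromatic carbon. Going by the values given here, no measured step therefore bears on this change, and nothing in the numbers points in either direction. The expectation for the step of a number 0.3 percentage points lower from compound 3 to compound 4 (within the scatter) is one within the scatter. Compound 4 is estimated to give 18%, in a range from 5% to 35%.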

Compound 4, a percentage reported as inhibition, at one concentration (the size of the read-out at that concentration, not a potency): 27.4%
Compound 4: middle estimate off by 9.4 percentage points, on the low side, and the stated range covers the measured number.
By their numbers in this assay, from the lowest: compounds 3 and 4 (each within the scatter of the next); then compound 1. At a limit, below all of these: compound 2.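

Going by these compounds alone, this is the first step on the anilino ring rather than on the double-bonded chain carbon, and in this assay it gives a number 9.1 percentage points higher from compound 3 to compound 4 (within the scatter). With 1H-pyrrol-2-yl kept in place, the change from phenyl to 3-nitrophenyl therefore stays inside the scatter, unlike the exchange on the chain carbon that gave a number 19.8 percentage points lower from compound 1 to compound 3 (beyond the scatter). No measurement shown here bears on the reason for this result.

From the compounds shown here alone, it remains open whether nitro would read the same on this ring when the chain carbon carries 3,4-dihydroxyphenyl, as in compound 1, or when it sits on another aromatic carbon of the ring. Going by these compounds, how an amine or a methoxy group would read on the same aromatic carbon also stays open.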